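Swapping chloro for butoxy on the aryl ring

This account rests on a few compounds, and the source may have more. Where it says the series, first, only, none or still open, it means among the compounds named here.

Compound 1, `O/N=C(/Nc1cccc(Cl)c1)c1ccc2occc2c1`, is the starting point. In an assay on isolated protein for inhibition of Indoleamine 2,3-dioxygenase 1 (Homo sapiens), read by spectrophotometry (a higher number here means a weaker inhibitor, a lower number a stronger inhibitor), compound 1 gives 690 nM, the lowest of the two numbers shown. Its nearest neighbour is compound 2, `O/N=C(/Nc1ccc(F)c(Cl)c1)c1ccc2occc2c1`, which in this assay gives 5200 nM; the step of a 7.5-fold higher number from compound 1 to compound 2 (0.88 log units; beyond the scatter) is a modest weakening brought by a fluoro in place of hydrogen on an aromatic carbon. Compound 3, `O/N=C(/Nc1ccc(Cl)c(F)c1)c1ccc2occc2c1`, reaches only a limit of the assay, giving > 30000 nM. That limit, (the limit of > 30000 nM in this assay, at which 1 of the 3 values shown sits), is the point beyond which no number is reported.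

Compound 4, `CCCCOc1cccc(N/C(=N/O)c2ccc3occc3c2)c1`, is not yet measured. It differs from compound 1 by butoxy in place of chloro on an aromatic carbon, sitting on an aromatic carbon of a six-membered aromatic ring of carbon only, meta to a large group. For the measured compounds named here, the only measured step in this set, the one from compound 1 to compound 2, concerns a fluoro added elsewhere on that ring and is the nearest guide available; no measured step covers exchanging chloro for an alkoxy chain. The step to compound 4 is therefore expected to be small to modest, most likely toward a higher number, as a 2.2-fold higher number from compound 1 to compound 4 (0.34 log units; beyond the scatter). Compound 4 is estimated to give 1500 nM in this assay, within a range from 300 nM to 8000 nM.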

Compound 4, half-maximal inhibitory concentration: > 30000 nM
Compound 4 ended at the assay's limit; the forecaster's own chance of this, stated with the estimate: 10%; middle value at least 20-fold (1.30 log units) from the limit.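

Exchanging chloro for butoxy on this aromatic carbon, meta to a large group, is the first change shown that replaces the chloro itself, and in this assay it gives an at least 43-fold higher number from compound 1 to compound 4 (1.63 log units; beyond the scatter). The value of compound 4, > 30000 nM, is a limit of the assay and not a number, and compound 3 sits at that same limit: the limit of > 30000 nM in this assay, at which 2 of the 4 values shown sit. The earlier step, a 7.5-fold higher number from compound 1 to compound 2 (0.88 log units; beyond the scatter), showed only what an added fluoro does with the chloro still in place, whereas this one shows that a butoxy of 5 heavy atoms in place of a chloro of 1 heavy atom costs far more on the same core.

As far as these compounds go, a single replacement cannot separate the effect of the oxygen from that of the chain, so it remains open whether a methoxy, with the same oxygen and a much shorter chain, or a butyl, with a chain and no oxygen, would stay closer to compound 1. From the compounds shown here alone, how a small group of another kind, such as a methyl, a nitrile or an amine, would behave at this position is also open.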